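The source may hold more compounds than are shown below. What is called first, only, known or untested is meant among the compounds shown, and "the series" means these compounds.

In a functional assay on HBL-100 cells (Homo sapiens) for antiproliferative activity, read by sulforhodamine B assay, with a stated time of 48 h (on this read-out lower numbers stand for stronger inhibition of growth and higher numbers for weaker inhibition of growth), compound 2 (`COC(=O)C#CC(O/C=C/C(=O)OC)C1CCCCC1`) gives 2500 nM. Compound 1 (`CCOC(=O)C#CC(O/C=C/C(=O)OCC)C(C)C`) gives 3000 nM, and compound 3 (`COC(=O)C#CC(CCc1ccccc1)O/C=C/C(=O)OC`) gives 2600 nM. These three numbers lie within the ordinary scatter of repeated measurements, so compound 2 stands level with both and the three cannot be ranked. Still unmeasured is compound 4 (`COC(=O)C#CC(O/C=C/C(=O)OC)C(C)C`), which differs from compound 2 at one place: isopropyl in place of cyclohexyl on a saturated chain carbon bound to an oxygen on an unsaturated carbon and a triple-bonded carbon. The change is isopropyl in place of cyclohexyl on a saturated chain carbon bound to an oxygen on an unsaturated carbon and a triple-bonded carbon. For the measured compounds named here, no measured pair differs at only one place, so the expectation rests on how closely the three values cluster even though their structures differ. In this assay, no step beyond the scatter is therefore expected, in either direction. The expected step, a 1.1-fold higher number from compound 2 to compound 4 (0.05 log units; within the scatter), is estimated to remain within that scatter. Compound 4 is expected to give about 2800 nM, with an estimated range from 1400 nM to 5500 nM.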

Compound 4, concentration for 50% growth inhibition: 450 nM
Compound 4: the middle estimate sits 6.2-fold (0.79 log units) above what was measured; measured number below the stated range.
By their numbers in this assay, from the lowest: compound 4; then compounds 2, 3 and 1 (each within the scatter of the next).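

In this assay, for the compounds shown here, putting isopropyl in place of cyclohexyl gives a 5.6-fold lower number from compound 2 to compound 4 (0.74 log units; beyond the scatter) and this is the first pair here that differs at one place only. Going by these compounds alone, the close values of the earlier compounds therefore did not mean that the group on this saturated chain carbon is unimportant: with the rest of the structure held fixed, changing this group alone clearly shifts growth inhibition. No measurement shown here explains the step.

The change both removes the six-membered ring and reduces the group from 6 heavy atoms to 3, so this single pair cannot show which of the two matters. A cyclopropyl group, which keeps a ring with fewer carbons, or a methyl group or longer chain at this place could help separate the two and show how far the trend extends.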